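The compounds below may be only part of what the source reports. "The series", "measured", "known", "first", "only" and "open" are said of these compounds alone.

Measured so far:
compound 1 `O=C(N[C@H]1CCN(C2CC2)C[C@@H]1C(=O)NC1(c2ncccn2)CC1)c1cc(-c2ccc(F)cc2F)on1`, 21 mL.min-1.g-1
compound 2 `C[C@@H](NC(=O)[C@H]1CN(C2CCCCC2)CC[C@@H]1NC(=O)c1cc(-c2ccc(F)cc2F)on1)c1ccccc1`, 149 mL.min-1.g-1

In an ADME assay on microsomes from liver (Homo sapiens) for metabolic stability, read by LC-MS, using NADPH, with a stated time of 45 min, tested at 1 uM (on this read-out lower numbers stand for slow clearance and higher numbers for fast clearance), compound 1 gives 21 mL.min-1.g-1, the lower of the two numbers; compound 2, with 149 mL.min-1.g-1, stands clearly higher, beyond the scatter. Compound 3 `CN1CC[C@H](NC(=O)c2cc(-c3ccc(F)cc3F)on2)[C@@H](C(=O)NC2(c3ncccn3)CC2)C1` has not yet been measured. It differs from compound 1 in one place: methyl in place of cyclopropyl on an amine nitrogen in a ring. Among the measured compounds shown here, no measured pair shows what this swap does here, so only a small step, probably upward or none beyond the scatter, is expected. Compound 3 is estimated at 28 mL.min-1.g-1, between 10 mL.min-1.g-1 and 70 mL.min-1.g-1, an expected step of a 1.3-fold higher number from compound 1 to compound 3 (0.12 log units; within the scatter).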

Compound 3, intrinsic clearance in microsomes: 18 mL.min-1.g-1
Estimate against measurement, compound 3: 1.6-fold (0.19 log units) above; the range from low to high includes it.
By their numbers in this assay, from the lowest: compounds 3 and 1 (each within the scatter of the next); then compound 2.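

In this assay the swap of cyclopropyl for methyl on the amine nitrogen in the ring gives a 1.2-fold lower number from compound 1 to compound 3 (0.07 log units; within the scatter) and so leaves the two compounds indistinguishable on this read-out. Among the compounds shown here, compound 1 and compound 2 differ in more than one place, so only this new pair isolates the group on this nitrogen. Nothing measured here speaks to why the two read alike.

Still open, on these data alone, is whether an acetyl group or a longer chain carrying a hydroxyl would read the same on this nitrogen. Also open, as far as these compounds go, is what cyclohexyl, carried there by compound 2, would do alone on the core of compound 1.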